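Amide nitrogen substituent: cyclopentyl to methyl on the shared core

The source may report more compounds than this note shows. Statements on the series, on what has been measured and on what is new or still open speak of the compounds shown alone.

Compound 2 `Nc1c(C(=O)NC2CCCC2)oc2nc(-c3ccccc3)cc(C(F)(F)F)c12` gives 32400 nM in a functional assay on HepG2 cells (Homo sapiens) for antiproliferative activity, read by MTT assay; a higher number here means a weaker inhibitor, a lower number a stronger inhibitor. Compound 1 `CCNC(=O)c1oc2nc(-c3ccccc3)cc(C(F)(F)F)c2c1N` gives 42800 nM in this assay. Of these two numbers compound 2 carries the lower one, but the step of a 1.3-fold lower number from compound 1 to compound 2 (0.12 log units; within the scatter) places the pair within the scatter, so neither stands apart from the other. Compound 3 `CNC(=O)c1oc2nc(-c3ccccc3)cc(C(F)(F)F)c2c1N` remains to be measured in this assay; it differs from compound 2 by methyl in place of cyclopentyl on an amide-type nitrogen. Going by the values given here, the only measured step that bears on this change is the one at the same amide-type nitrogen, from ethyl to cyclopentyl, which stayed within the scatter. Shortening the group at that place to methyl therefore carries no expectation of a step beyond the scatter in either direction. The estimate for compound 3 is 45000 nM, with a range from 20000 nM to 100000 nM. The expected step of a 1.4-fold higher number from compound 2 to compound 3 (0.14 log units; within the scatter) amounts to no real change.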

Compound 3, half-maximal inhibitory concentration: 41200 nM
Compound 3: middle estimate off by 1.1-fold (0.04 log units), on the high side; measured number inside the range.
By their numbers in this assay, from the lowest: compounds 2, 3 and 1 (each within the scatter of the next).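

The amide-type nitrogen now carries three groups, and in this assay the smallest of them, methyl, stays level with both larger ones: cyclopentyl (a 1.3-fold higher number from compound 2 to compound 3 (0.10 log units; within the scatter)) and ethyl (a 1.0-fold lower number from compound 1 to compound 3 (0.02 log units; within the scatter)). Both steps lie within the scatter, so replacing the five-membered carbon ring with a single carbon, like trimming ethyl to methyl, gives no readable difference, and none of the three compounds goes against this. No measurement on hand offers an explanation for this lack of separation.

Still open, going by these compounds, is whether a group of another kind on this nitrogen, such as benzyl, a carboxylic acid or an amine-bearing chain, would step beyond the scatter. Also open, on these data alone, is whether replacing the phenyl or trifluoromethyl on the shared core would do so.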